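A few compounds are considered here, and "the series" means these few. Any claim that something is new, unique, unknown or untested is made for them only; others in the source may bear on it.

In a functional assay on MDA-MB-231 cells (Homo sapiens) for cytotoxicity, read by MTT assay, with a stated time of 72 h (on this read-out higher numbers stand for weaker inhibition and lower numbers for stronger inhibition), compound 1 `CN(C)CCCCCn1c2c(c3ccccc31)C(=O)c1c[n+]([O-])c3ccccc3c1C2=O` gives 240 nM and compound 2 `CC1(C)OCC(Cn2cc(Cn3c4c(c5ccccc53)C(=O)c3c[n+]([O-])c5ccccc5c3C4=O)nn2)O1` gives 230 nM, so compound 2 stands level with compound 1, within the scatter. Compound 3 `O=C1c2c[n+]([O-])c3ccccc3c2C(=O)c2c1c1ccccc1n2Cc1cn(CC(O)CO)nn1` differs from compound 2 by 1,2-dihydroxyethyl in place of 2,2-dimethyl-1,3-dioxolan-4-yl on a saturated chain carbon bound to an aromatic nitrogen, with 1,2-dihydroxyethyl in place of 2,2-dimethyl-1,3-dioxolan-4-yl on a saturated chain carbon bound to an aromatic nitrogen. For the measured compounds named here, no measured pair shows this change, so the expectation rests only on the closeness of compound 1 at 240 nM and compound 2 at 230 nM. The expected change in this assay, a 1.1-fold higher number from compound 2 to compound 3 (0.05 log units; within the scatter), stays within the scatter, with no direction beyond it. Compound 3 is estimated at 260 nM, within a range of 90 nM to 700 nM.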

Compound 3, half-maximal inhibitory concentration: 1290 nM
Beside the measured number, compound 3's estimate is 5.0-fold (0.70 log units) below it; measured number above the stated range.
By their numbers in this assay, from the lowest: compounds 2 and 1 (each within the scatter of the next); then compound 3.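

In this assay, 1,2-dihydroxyethyl in place of 2,2-dimethyl-1,3-dioxolan-4-yl gives a 5.6-fold higher number from compound 2 to compound 3 (0.75 log units; beyond the scatter) on a saturated chain carbon bound to an aromatic nitrogen, so the number here does depend on the group carried, which the level values of compounds 1 and 2 did not show. The 1-(2,3-dihydroxypropyl)-1H-1,2,3-triazol-4-yl group in place of 4-(dimethylamino)butyl likewise gives a 5.4-fold higher number from compound 1 to compound 3 (0.73 log units; beyond the scatter) in this comparison. Nothing measured here bears on why the number rises.

The compounds shown leave open how a 2-methoxyethyl group, a 2-hydroxyethyl group or a 2-aminoethyl group would read at this place on the triazole.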